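From Formyl to Acetyl on a Shared Aromatic Core

The source may hold more compounds than are shown below. What is called first, only, known or untested is meant among the compounds shown, and "the series" means these compounds.

Compound 1 `CC(Oc1ccccc1C=O)C1=NCCN1` carries a formyl group on its aromatic ring. In a functional assay on CHO cells for agonist activity at Alpha-2C adrenergic receptor (Homo sapiens) (on this read-out higher numbers stand for an effect only at larger amounts of compound and lower numbers for an effect already at smaller amounts), compound 1 gives 100 nM. Compound 2 `CC(C)Oc1ccccc1OC(C)C1=NCCN1`, which has isopropoxy in place of formyl on an aromatic carbon, gives 100 nM, so that no change at the digits printed from compound 1 to compound 2 (within the scatter). Compound 3 `CC(Oc1ccccc1S(C)(=O)=O)C1=NCCN1`, with methylsulfonyl in place of formyl on an aromatic carbon, gives 316 nM, and a 3.2-fold higher number from compound 1 to compound 3 (0.50 log units; beyond the scatter); in the same way a 3.2-fold higher number from compound 2 to compound 3 (0.50 log units; beyond the scatter). Compound 1 thus sits level with compound 2 among the three numbers, and compound 3 stands apart from both.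

Compound 4 `CC(=O)c1ccccc1OC(C)C1=NCCN1` is the compound still to be measured. (methyl in place of hydrogen on a carbonyl carbon). Within the data shown here, no measured step covers exactly this change; the two steps that start from compound 1 replace the whole formyl group rather than adding to it. Even so, those steps show that this position on the core tolerates quite different groups with either no change or only a modest rise, and adding methyl to the formyl carbon is a smaller alteration than either of them. The expected step of a 1.5-fold higher number from compound 1 to compound 4 (0.18 log units; within the scatter) is therefore small and could fall on either side, most likely within the scatter or a little higher. Compound 4 is estimated at 150 nM in this assay, expected to lie between 50 nM and 500 nM.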

Compound 4, half-maximal effective concentration: 200 nM
For compound 4 the middle estimate is 1.3-fold (0.12 log units) below the measured one; low and high end bracket the measured number.
By their numbers in this assay, from the lowest: compounds 1, 2, 4 and 3 (each within the scatter of the next, the first and the last beyond it).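

Among these compounds, this is the first direct test of enlarging the formyl group rather than replacing it: turning formyl into acetyl adds a single methyl on the carbonyl carbon, and this assay gives a step that stays within the scatter (a 2.0-fold higher number from compound 1 to compound 4 (0.30 log units; within the scatter)). Acetyl also cannot be told apart from the isopropoxy group (a 2.0-fold higher number from compound 2 to compound 4 (0.30 log units; within the scatter)) or from the methylsulfonyl group (a 1.6-fold lower number from compound 3 to compound 4 (0.20 log units; within the scatter)), so compound 4 is within the scatter of compound 3 even though compound 1 and compound 2 are not. At this position, therefore, acetyl does not settle on either side of the modest gap seen earlier, and no accompanying measurement offers any explanation for this result.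

The compounds shown leave open whether a longer chain on the carbonyl carbon, such as ethyl or propyl in place of the methyl, would still give a step within the scatter. They also leave open how a carboxylic acid or an amine at this same place on the shared core would read out in this assay and whether either would separate clearly from the groups seen so far.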